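Lipophilicity from compound 2 to compound 3

The source may report more compounds than this note shows. Statements on the series, on what has been measured and on what is new or still open speak of the compounds shown alone.

Compound 2 (`CC[C@@H](Nc1c(C#N)c(-c2ccc(-c3ccc(OC)cc3)cc2)nc2cnccc12)C(N)=O`) stands in a physicochemical assay for lipophilicity, read by HPLC, at pH 7.5 (on this read-out higher numbers stand for higher lipophilicity and lower numbers for lower lipophilicity), at 2.7, level with compound 1 (`CC[C@@H](Nc1c(C#N)c(-c2ccc(-c3ccccc3F)cc2)nc2cnccc12)C(N)=O`) at 2.7. Compound 3 (`CC[C@@H](Nc1c(C#N)c(-c2ccc(-c3ccccc3N(C)C)cc2)nc2cnccc12)C(N)=O`) carries 2-(dimethylamino)phenyl in place of 4-methoxyphenyl on an aromatic carbon, para to a large group: 2-(dimethylamino)phenyl in place of 4-methoxyphenyl on an aromatic carbon. For the measured compounds named here, the only measured step at this place is no change at the digits printed from compound 1 to compound 2 (within the scatter), which stays within the scatter. Going by the values given here, no measured compound carries 2-(dimethylamino)phenyl, so this evidence is thin. The expected step in this assay is a number 0.20 log units higher from compound 2 to compound 3 (within the scatter), with none expected beyond the scatter. The estimate for compound 3 is 2.9, with an expected range of 2.5 to 3.4.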

Compound 3, distribution coefficient: 3.2
Compound 3: middle estimate off by 0.30 log units, on the low side; measured number inside the range.
By their numbers in this assay, from the lowest: compounds 1 and 2 (each within the scatter of the next); then compound 3.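

In this assay this position is no longer flat: the earlier swap stayed within the scatter, whereas 2-(dimethylamino)phenyl gives a number 0.50 log units higher from compound 2 to compound 3 (beyond the scatter) and a number 0.50 log units higher from compound 1 to compound 3 (beyond the scatter) in the same direction. Dimethylamino in place of fluoro is therefore the first change here to move the read-out beyond the scatter, though that rests on one compound. No measurement on hand accounts for the rise.

Open, as far as these compounds go, is whether a primary amine or a carboxylic acid in place of dimethylamino would keep, lose or reverse this rise. From the compounds shown here alone, whether the step holds on another core also stays open, as all three compounds share one.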